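Replacing diethylamino in compound 1: working notes

The compounds below may be only part of what the source reports. "The series", "measured", "known", "first", "only" and "open" are said of these compounds alone.

Values in a functional assay on cells (Neutrophil, Homo sapiens) for inhibition, read by transwell migration; on this read-out higher numbers stand for weaker inhibition and lower numbers for stronger inhibition:
- compound 1 `CCOC(=O)c1c(NCCN(CC)CC)n(-c2ccccc2)c(=S)n(-c2ccccc2)c1=O`: 0.02 nM
- compound 2 `CCN(CC)CCNc1c(C(=O)OC(C)C)c(=O)n(-c2ccccc2)c(=S)n1-c1ccccc1`: 0.21 nM

Compound 1 holds the lower of the two numbers, and an 11-fold higher number from compound 1 to compound 2 (1.02 log units; beyond the scatter) marks a large gap. Compound 3 `CCOC(=O)c1c(NCCC2CCCN2C)n(-c2ccccc2)c(=S)n(-c2ccccc2)c1=O` departs from compound 1 by 1-methylpyrrolidin-2-yl in place of diethylamino on a saturated chain carbon, two bonds along the chain from a nitrogen on an aromatic ring, so 1-methylpyrrolidin-2-yl takes the place of diethylamino.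

Among the measured compounds shown here, no measured step touches this group, since compound 1 and compound 2 both carry diethylamino. For the measured compounds named here, the one measured step shows only that this assay can respond strongly to a single change. It gives no direction for the present change. Going by the values given here, with compound 1 at 0.02 nM, the low end of the numbers so far, a moderate move to a higher number is expected, smaller than the measured step.

The expected step is a 3.0-fold higher number from compound 1 to compound 3 (0.48 log units; beyond the scatter). For compound 3 the estimated value is 0.06 nM, with an expected range of 0.01 nM to 0.4 nM.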

Compound 3, half-maximal inhibitory concentration: 1.61 nM
Compound 3: the middle estimate sits 27-fold (1.43 log units) below what was measured, and the stated range ends below it.
By their numbers in this assay, from the lowest: compound 1; then compound 2; then compound 3.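

In this assay, the diethylamino group is not a free place for change: 1-methylpyrrolidin-2-yl in its place gives an 81-fold higher number from compound 1 to compound 3 (1.91 log units; beyond the scatter), although the group only moves from 5 heavy atoms to 6, gains a five-membered non-aromatic ring, and keeps the same counts of hydrogen-bond donors and acceptors. The end of this side chain can therefore move the number by a large step from compound 1, which the ester change alone could not show. Nothing measured here accounts for the size of this step.

The compounds shown leave open whether dimethylamino, or pyrrolidin-1-yl with its ring joined through the nitrogen, would keep the number of compound 1 at this place. Also open, as far as these compounds go, is whether the same exchange would have a similar effect on the ester of compound 2.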